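This account rests on a few compounds, and the source may have more. Where it says the series, first, only, none or still open, it means among the compounds named here.

Compound 1 `O=C(CCc1nc2ccccc2c(=O)[nH]1)N/N=C/c1ccc([N+](=O)[O-])cc1` gives 220000000 nM
Compound 2 `O=C(CCc1nc2ccccc2c(=O)[nH]1)N/N=C/c1ccc(O)cc1` gives 105000000 nM
Compound 3 `O=C(CCc1nc2ccccc2c(=O)[nH]1)N/N=C/c1ccccc1` gives 265000000 nM

These numbers come from a physicochemical assay, read by spectrophotometry, with a stated time of 6 min (a lower number here means a stronger inhibitor, a higher number a weaker inhibitor), and the three compounds differ in one aromatic group only. Compound 3 carries plain phenyl and sits level with compound 1 (the gap, a 1.2-fold higher number from compound 1 to compound 3 (0.08 log units; within the scatter), is small). Compound 2 stands apart from them, and a 2.5-fold higher number from compound 2 to compound 3 (0.40 log units; beyond the scatter) is a modest step.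

The next compound is compound 4 `COc1cc(/C=N/NC(=O)CCc2nc3ccccc3c(=O)[nH]2)ccc1O` and the change is 4-hydroxy-3-methoxyphenyl in place of phenyl on a carbon with a double bond to nitrogen.

Among the compounds with values here, two measured steps bear on this. Compound 2 holds hydroxy where compound 3 holds hydrogen, and a 2.5-fold higher number from compound 2 to compound 3 (0.40 log units; beyond the scatter) shows the size of that difference. Read backwards, it suggests that adding hydroxy lowers the number. Compound 2 also differs from compound 1 by a similar amount (a 2.1-fold lower number from compound 1 to compound 2 (0.32 log units; beyond the scatter)) when hydroxy replaces nitro. Within the data shown here, no measured step covers methoxy, so it widens the uncertainty without setting a direction.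

A modest fall is therefore expected, an estimated 2.0-fold lower number from compound 3 to compound 4 (0.31 log units; beyond the scatter) in this assay. Compound 4 is estimated at 130000000 nM, with an expected range from 55000000 nM to 300000000 nM.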

Compound 4, half-maximal inhibitory concentration: 95000000 nM
Beside the measured number, compound 4's estimate is 1.4-fold (0.14 log units) above it; the measured number falls inside the stated range.
By their numbers in this assay, from the lowest: compounds 4 and 2 (each within the scatter of the next); then compounds 1 and 3 (each within the scatter of the next).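

In this assay the change to 4-hydroxy-3-methoxyphenyl gives a 2.8-fold lower number from compound 3 to compound 4 (0.45 log units; beyond the scatter) and, set against 4-nitrophenyl, it gives a 2.3-fold lower number from compound 1 to compound 4 (0.36 log units; beyond the scatter) as well, so a second compound carrying hydroxy now sits clear of both compounds that lack it. Methoxy adds nothing that can be told apart on top of hydroxy: its step is a 1.1-fold lower number from compound 2 to compound 4 (0.04 log units; within the scatter) and lies within the scatter, so compound 2 and compound 4 stand level. Across these four compounds, then, hydroxy on the aromatic ring goes with the lower numbers, no compound goes against that, and methoxy is tolerated alongside it, but no independent measurement is available to explain any of this.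

The compounds shown leave open whether methoxy on a plain phenyl, without hydroxy, would move the number at all, and so whether hydroxy alone accounts for the fall seen with 4-hydroxy-3-methoxyphenyl. They also leave open whether an amine or a carboxylic acid in the place of hydroxy would give a similar step, or whether a longer chain carrying the hydroxy would keep it.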